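A few compounds are considered here, and "the series" means these few. Any claim that something is new, unique, unknown or untested is made for them only; others in the source may bear on it.

Measured compounds:
- compound 1, `O=C(CSC(=S)N[C@H]1CCOC1=O)Nc1ccc(Cl)cc1`, 50300 nM 
- compound 2, `O=C(CSC(=S)N[C@H]1CCOC1=O)Nc1ccccc1`, > 128000 nM 
- compound 3, `O=C(CSC(=S)N[C@H]1CCOC1=O)Nc1ccc(C(=O)/C=C/c2ccc(Cl)cc2)cc1`, 20300 nM 

All three were tested in a functional assay on MCF7 cells (Homo sapiens) for cytotoxicity, read by MTT assay, with a stated time of 72 h; on this read-out higher numbers stand for weaker inhibition and lower numbers for stronger inhibition. Compound 1 gives 50300 nM. For compound 2 the value > 128000 nM is a limit of the assay and not a number. Compound 3 gives 20300 nM.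

Compound 1 and compound 2 differ by hydrogen in place of chloro on an aromatic carbon, and this gives an at least 2.5-fold higher number from compound 1 to compound 2 (0.40 log units; beyond the scatter). This step can only be given as a lower bound, because of the limit of > 128000 nM in this assay, at which 1 of the 3 values shown sits.

Compound 3 carries a larger group than compound 1, and the difference between the two cores is not broken down here. Compound 3 shows the lower number of the two, and the gap to compound 1 is beyond the usual scatter.

Compound 4, `O=C(CSC(=S)N[C@H]1CCOC1=O)Nc1ccc(C(=O)/C=C/c2ccccc2)cc1`, has not yet been measured. It differs from compound 3 by hydrogen in place of chloro on an aromatic carbon. Going by the values given here, this is the same change as the one from compound 1 to compound 2, made on the same kind of place, but in compound 4 the group affected also reads as 2-(4-chlorophenyl)ethenyl going to 2-phenylethenyl.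

Among the compounds with values here, since the earlier change gave an at least 2.5-fold higher number from compound 1 to compound 2 (0.40 log units; beyond the scatter), a step of a 2.5-fold higher number from compound 3 to compound 4 (0.39 log units; beyond the scatter) is expected here, of similar direction but set with caution: only one earlier example of this change exists. Compound 4 is therefore estimated at 50000 nM, with a likely range from 20000 nM to 130000 nM.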

Compound 4, half-maximal inhibitory concentration: 44300 nM
The estimate for compound 4 lay 1.1-fold (0.05 log units) above the measured number; the range from low to high includes it.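

In this assay, the change from chloro to hydrogen on the aromatic ring raises the number on both cores, here as a 2.2-fold higher number from compound 3 to compound 4 (0.34 log units; beyond the scatter), and the comparison with the earlier step reads: the same change on two cores in this assay, an at least 2.5-fold higher number (0.40 log units; beyond the scatter) from compound 1 to compound 2 and a 2.2-fold higher number (0.34 log units; beyond the scatter) from compound 3 to compound 4; the limit leaves it open whether they differ The value for compound 2 is a limit and not a number, which leaves the earlier step as a lower bound only: the limit of > 128000 nM in this assay, at which 1 of the 4 values shown sits. These two pairs show that the direction of the change carried over from one core to the other, but they do not show that its size was the same, and they say nothing about cores beyond these two.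

Also open is what the (2-phenylethenyl)carbonyl group itself contributes: in place of hydrogen it gives an at least 2.8-fold lower number from compound 2 to compound 4 (0.46 log units; beyond the scatter), while in place of chloro it gives a 1.1-fold lower number from compound 1 to compound 4 (0.06 log units; within the scatter), and these steps alone do not explain that contrast. The compounds shown also leave open how a bromo group, a methoxy group or an amine in place of that chloro would read on either core.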